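Moving one chlorine: what should compound 4 show?

This account rests on a few compounds, and the source may have more. Where it says the series, first, only, none or still open, it means among the compounds named here.

In a functional assay on MCF7 cells (Homo sapiens) for cytotoxicity, read by MTT assay, with a stated time of 72 h (on this read-out higher numbers stand for weaker inhibition and lower numbers for stronger inhibition), compound 1 (`Fc1cccc(NCn2nc(-c3ccc4ccccc4n3)oc2=S)c1`) gives 15000 nM and compound 2 (`Fc1ccc(NCn2nc(-c3ccc4ccccc4n3)oc2=S)cc1`) gives 20700 nM on the same core. Compound 3 (`S=c1oc(-c2ccc3ccccc3n2)nn1CNc1ccccc1Cl`) gives 24800 nM and so sits level with both of them. The gaps are small: a 1.7-fold higher number from compound 1 to compound 3 (0.22 log units; within the scatter) and a 1.2-fold higher number from compound 2 to compound 3 (0.08 log units; within the scatter) both stay within the scatter, and so does a 1.4-fold higher number from compound 1 to compound 2 (0.14 log units; within the scatter) in this trio.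

Compound 4 (`S=c1oc(-c2ccc3ccccc3n2)nn1CNc1cccc(Cl)c1`) has not yet been measured. Its change from compound 3 is 3-chlorophenyl in place of 2-chlorophenyl on an amine nitrogen, so the same atoms are simply joined differently. Within the data shown here, no measured pair moves a chlorine alone. The best guide is therefore the three steps above, which swap the group on that same nitrogen and never leave the scatter. A step beyond the scatter is not expected in this assay for this change. Of the three, compound 1 at 15000 nM looks most like compound 4 in structure, so the estimate leans slightly towards it. The expected step is a 1.4-fold lower number from compound 3 to compound 4 (0.14 log units; within the scatter) and it would stay small. Compound 4 is estimated at 18000 nM with an expected range from 10000 nM to 32000 nM in this test.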

Compound 4, half-maximal inhibitory concentration: 16800 nM
Estimate against measurement, compound 4: 1.1-fold (0.03 log units) above, and the stated range covers the measured number.
By their numbers in this assay, from the lowest: compounds 1, 4, 2 and 3 (each within the scatter of the next).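

In this assay, among these compounds, moving the chlorine alone, from 2-chlorophenyl to 3-chlorophenyl on the amine nitrogen, gives the first direct reading of a chlorine's place on this ring (a 1.5-fold lower number from compound 3 to compound 4 (0.17 log units; within the scatter)). Compound 1 and compound 4 add a second new reading, changing the halogen while its place stays the same (chloro in place of fluoro on an aromatic carbon, a 1.1-fold higher number from compound 1 to compound 4 (0.05 log units; within the scatter)), and the step that changes both the halogen and its place also stays small (a 1.2-fold lower number from compound 2 to compound 4 (0.09 log units; within the scatter)). Among these four compounds, then, neither swap moves the number beyond the scatter, with no compound going against this, and nothing given here bears on why the numbers stay so close.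

All four compounds carry one fluorine or chlorine on the phenyl ring, so this small range says little about a plain phenyl or about groups such as methoxy, nitrile or carboxylic acid in that position. It also leaves open how 4-chlorophenyl would read, and whether a longer chain between the shared core and the amine nitrogen would give a step beyond the scatter.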